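The source may report more compounds than this note shows. Statements on the series, on what has been measured and on what is new or still open speak of the compounds shown alone.

Measured compounds:
Compound 1 `Cc1ccccc1CNCC1(O)CCN(CCCc2c[nH]c3ccc(-n4cnnc4)cc23)CC1` gives 83 nM in an assay on CHO cells with 5-hydroxytryptamine receptor 1B (Homo sapiens) as the target; on this read-out higher numbers stand for weaker inhibition and lower numbers for stronger inhibition.
Compound 2 `CC(=O)Nc1ccc(CNCC2(O)CCN(CCCc3c[nH]c4ccc(-n5cnnc5)cc34)CC2)cc1` gives 30 nM in this assay.

Among these two numbers compound 2 stands lowest in this assay, the only neighbour being compound 1, which is set apart by a 2.8-fold lower number from compound 1 to compound 2 (0.44 log units; beyond the scatter), a modest step in which 4-acetamidophenyl replaced 2-methylphenyl on a saturated chain carbon bound to an amine nitrogen.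

Compound 3 `Cc1ccccc1CN(C)CC1(O)CCN(CCCc2c[nH]c3ccc(-n4cnnc4)cc23)CC1` has not been measured. It differs from compound 2 by methyl(2-methylbenzyl)amino in place of (4-acetamidobenzyl)amino on a saturated chain carbon bound to a saturated ring carbon. Going by the values given here, of this change, the return from the 4-acetamidobenzyl group to a 2-methylbenzyl group is the reverse of the one measured step, a 2.8-fold lower number from compound 1 to compound 2 (0.44 log units; beyond the scatter), so that part alone would carry compound 3 back toward compound 1. The added methyl on the amine nitrogen has no measured counterpart here, so no shown step informs its effect.

Compound 3 is therefore expected to land near compound 1, with a 3.7-fold higher number from compound 2 to compound 3 (0.56 log units; beyond the scatter) in this assay. The estimate for compound 3 is 110 nM, with a range from 35 nM to 400 nM.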

Compound 3, half-maximal inhibitory concentration: 89 nM
Beside the measured number, compound 3's estimate is 1.2-fold (0.09 log units) above it, within the range that was stated.
By their numbers in this assay, from the lowest: compound 2; then compounds 1 and 3 (each within the scatter of the next).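

In this assay the amine nitrogen gains its first reading: methyl in place of hydrogen there, with the 2-methylbenzyl group kept (a 1.1-fold higher number from compound 1 to compound 3 (0.03 log units; within the scatter)), leaves compound 3 and compound 1 level within the scatter, so this nitrogen tolerates the added methyl in this series. Compound 2, with its (4-acetamidobenzyl)amino group, now stands lowest of the three, since the change to methyl(2-methylbenzyl)amino on the saturated chain carbon bound to a saturated ring carbon also gives a step beyond the scatter (a 3.0-fold higher number from compound 2 to compound 3 (0.47 log units; beyond the scatter)), so the separation of compound 2 from the other two holds whether or not the 2-methylbenzyl amine nitrogen carries the methyl. No measurement at hand accounts for either step, or for the level result at the nitrogen.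

From the compounds shown here alone, what the added methyl does with the 4-acetamidobenzyl group in place remains open, as its effect has been read only with the 2-methylbenzyl group. Also open, going by these compounds, is how a longer chain such as ethyl on the amine nitrogen, or a carboxylic acid in place of the acetamido group on the benzyl ring, would read in this assay.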